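Removing the amino from a fluoroindole thioether

The source may hold more compounds than are shown below. What is called first, only, known or untested is meant among the compounds shown, and "the series" means these compounds.

Of the compounds shown here, three have so far been measured in an assay on isolated protein for inhibition of Myeloperoxidase (Homo sapiens), read by ELISA, with a stated time of 5 min; a higher number here means a weaker inhibitor, a lower number a stronger inhibitor.

compound 1 `NCCCCc1c[nH]c2c(F)cccc12`: compound 1 gives 21 nM.
compound 2 `NCCSCCc1c[nH]c2ccc(F)cc12`: compound 2 gives 8 nM.
compound 3 `NCCSCCCc1c[nH]c2c(F)cccc12`: compound 3 sits at the limit of > 100 nM in this assay, at which 1 of the 3 values shown sits, reported as > 100 nM, a limit and not a number.

Of the two numbers shown, compound 2 stands lowest; compound 1 sits at a higher number, and that gap lies beyond the scatter. Going by the values given here, the only measured step that changes a single place, an at least 4.7-fold higher number from compound 1 to compound 3 (0.67 log units; beyond the scatter), ends at a limit rather than a number and concerns a different change from the one considered here.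

Compound 4 `CCSCCc1c[nH]c2ccc(F)cc12` differs from compound 2 by hydrogen in place of amino on a saturated chain carbon, two bonds along the chain from a sulfur. Among the compounds with values here, every measured compound carries the amino, and no measured step removes it, so no step bears directly on this change; the expectation rests only on the fact that the amino is the one feature common to all three measured compounds and that the change takes it away. A weakening is expected from compound 2 to compound 4, a 25-fold higher number from compound 2 to compound 4 (1.40 log units; beyond the scatter), with the size of the step uncertain. Compound 4 is therefore estimated at 200 nM, within a range from 40 nM to 1000 nM.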

Compound 4, half-maximal inhibitory concentration: > 100 nM
Compound 4 gave a limit, no number; the forecaster's own chance of this, stated with the estimate: 50%; the middle value lies beyond the limit too.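

In this assay, going by these compounds alone, the amino group now has a measured step of its own: hydrogen in place of amino on a saturated chain carbon, two bonds along the chain from a sulfur, gives an at least 12-fold higher number from compound 2 to compound 4 (1.09 log units; beyond the scatter), a large change of a kind that no earlier step covered. The loss of this one group is enough to take compound 2, at 8 nM, out of the range where the assay gives a number, so the thioether chain and the fluorinated core do not hold that value without the amino. Compound 4 stands at > 100 nM, which is a limit and not a number, so the step gives only a lower bound on the size of the change, and compound 4 shares that limit with one other compound: the limit of > 100 nM in this assay, at which 2 of the 4 values shown sit.

On these data alone, it remains open whether a methylamine, a dimethylamine, a hydroxyl or a carboxylic acid at the end of the chain would keep or lose the value of the amino. As far as these compounds go, it is also open whether removing the amino costs as much on the all-carbon chain of compound 1, since this step rests on a single pair.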